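From Ethyl to (2-Hydroxyethyl)carbamoyl on the Shared Core

The source may hold more compounds than are shown below. What is called first, only, known or untested is meant among the compounds shown, and "the series" means these compounds.

Within the data shown here, in a functional assay on HCT-116 cells (Homo sapiens) for antiproliferative activity, read by sulforhodamine B assay, with a stated time of 72 h (a lower number here means a stronger inhibitor, a higher number a weaker inhibitor), compound 2 `CCC[C@@H]1C[C@@H](c2ccc(Cl)c(Cl)c2)[C@H](NC(=O)c2cc(-c3c(Cl)cnn3C)c(Cl)o2)CN1` gives 1020 nM, the lower of the two numbers measured so far. Among the measured compounds shown here, its only measured neighbour, compound 1 `Cn1ncc(Cl)c1-c1cc(C(=O)N[C@@H]2CN[C@H](CC(=O)NCC(O)CO)C[C@H]2c2ccc(Cl)c(Cl)c2)oc1Cl`, gives 7090 nM. For the measured compounds named here, compound 1 carries (2,3-dihydroxypropyl)carbamoyl where compound 2 carries ethyl, and this exchange is the single measured step: a 7.0-fold lower number from compound 1 to compound 2 (0.84 log units; beyond the scatter).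

Compound 3 `Cn1ncc(Cl)c1-c1cc(C(=O)N[C@@H]2CN[C@H](CC(=O)NCCO)C[C@H]2c2ccc(Cl)c(Cl)c2)oc1Cl` moves back in that direction, with (2-hydroxyethyl)carbamoyl in place of ethyl on a saturated chain carbon bound to a saturated ring carbon. Going by the values given here, the entering group resembles the one on compound 1 at 7090 nM, so a rise of similar size, towards weaker inhibition, is expected in this assay, though one step is thin evidence. The expected change is a 4.9-fold higher number from compound 2 to compound 3 (0.69 log units; beyond the scatter). For compound 3, the estimate is 5000 nM, with an expected range of 2300 nM to 10000 nM.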

Compound 3, half-maximal inhibitory concentration: 670 nM
Estimate against measurement, compound 3: 7.5-fold (0.87 log units) above; measured number below the stated range.
By their numbers in this assay, from the lowest: compounds 3 and 2 (each within the scatter of the next); then compound 1.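

In this assay, a 1.5-fold lower number from compound 2 to compound 3 (0.18 log units; within the scatter), so on this saturated chain carbon bound to a saturated ring carbon, (2-hydroxyethyl)carbamoyl and the much smaller ethyl cannot be told apart. The large change lies within the amide side chain itself: hydrogen in place of hydroxymethyl gives an 11-fold lower number from compound 1 to compound 3 (1.02 log units; beyond the scatter), which ties the weak result for the (2,3-dihydroxypropyl)carbamoyl group to that one hydroxymethyl rather than to the carbamoyl group as a whole. Nothing shown here explains why this small edit matters so much.

As far as these compounds go, it remains open whether the hydroxyl of (2-hydroxyethyl)carbamoyl contributes at all, which a plain ethylcarbamoyl group would test. The compounds also leave open how a carboxylic acid, an amine or a longer chain such as (3-hydroxypropyl)carbamoyl would behave at this place.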